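A few compounds are considered here, and "the series" means these few. Any claim that something is new, unique, unknown or untested is made for them only; others in the source may bear on it.

The compounds here share one core, and differ at two places. Compound 2 `Cc1occc1C(=O)N1CCC(NC(=O)Nc2ccc(OC(F)(F)F)cc2)CC1` carries a trifluoromethoxy group on an aromatic carbon. Going by the values given here, in a physicochemical assay for solubility, read by mass spectrometry, in phosphate buffer, with a stated time of 24 h, at pH 7.4 (a higher number here means a more soluble compound, a lower number a less soluble compound), compound 2 gives 8.6 ug/mL, the highest of the two numbers measured so far. Among the compounds with values here, its only neighbour, compound 1 `Cc1occc1C(=O)N1CCC(NC(=O)Nc2ccc(C(F)(F)F)cc2)CC1`, gives 0.28 ug/mL in this assay, and the step of a 31-fold higher number from compound 1 to compound 2 (1.49 log units; beyond the scatter) is the single measured step at hand. Compound 3 `O=C(Nc1ccc(OC(F)(F)F)cc1)NC1CCN(C(=O)c2cc[nH]c2)CC1` has not yet been measured. It differs from compound 2 at a different place: 1H-pyrrol-3-yl in place of 2-methylfuran-3-yl on a carbonyl carbon. Within the data shown here, no measured step touches the group on the carbonyl carbon, so the one measured step gives no direct guide here, and the expectation rests on the structural change alone. A modest step upward is expected, a 2.3-fold higher number from compound 2 to compound 3 (0.37 log units; beyond the scatter), though it may well fall within the scatter. Compound 3 is therefore estimated at 20 ug/mL, with a range from 6 ug/mL to 60 ug/mL.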

Compound 3, solubility: 43 ug/mL
Estimate against measurement, compound 3: 2.2-fold (0.33 log units) below, and the stated range covers the measured number.
By their numbers in this assay, from the lowest: compound 1; then compound 2; then compound 3.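

The group on the carbonyl carbon, which the earlier step left untouched, also moves the number in this assay: the change to 1H-pyrrol-3-yl gives a 5.0-fold higher number from compound 2 to compound 3 (0.70 log units; beyond the scatter), so both places where these compounds differ now show a step beyond the scatter. This one change alters several things together, namely the hetero atom in the ring, the hydrogen-bond donor and acceptor counts and the heavy-atom count, so the step cannot be assigned to any one of them. Nothing available here gives a measured reason for the rise.

As far as these compounds go, whether 1H-pyrrol-3-yl would give a similar step alongside the trifluoromethyl group of compound 1 remains open. Also open, from the compounds shown here alone, is how the number would respond if the carbonyl carbon carried a group of another kind, such as a ring bearing an amine or a carboxylic acid.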